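This account rests on a few compounds, and the source may have more. Where it says the series, first, only, none or still open, it means among the compounds named here.

Compound 1, `Cc1nc(S(C)(=O)=O)ccc1Oc1ncnc(OC2CCN(C(=O)OC(C)(C)C#N)CC2)c1F`, reaches a maximal response of 97% in a functional assay on isolated protein for inhibition of Glucose-dependent insulinotropic receptor (Rattus norvegicus), read by HTRF and cAMP accumulation; a higher number here means a larger maximal response, a lower number a smaller maximal response. Compound 2, `Cc1nc(S(C)(=O)=O)ccc1Oc1ncnc(OC2CCN(C(=O)O[C@@H](C)C(F)(F)F)CC2)c1F`, gives 80% in the same assay. Among the compounds with values here, the single change between them, 1-(trifluoromethyl)ethyl in place of 1-cyano-1-methylethyl on an oxygen next to a carbonyl group, produced a number 17 percentage points lower from compound 1 to compound 2 (beyond the scatter). Compound 2 thus holds the lower of the two measured numbers, and its nearest neighbour is compound 1.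

Compound 3, `Cc1nc(S(C)(=O)=O)ccc1Oc1ncnc(OC2CCN(C(=O)SC(C)C)CC2)c1F`, is not yet measured. It differs from compound 2 as follows: isopropylsulfanyl in place of 1-(trifluoromethyl)ethoxy on a carbonyl carbon. Within the data shown here, the only measured step is the one from compound 1 to compound 2, and it does not touch the kind of group that enters here; it shows only that exchanges on the carbonyl carbon side can move the response modestly. Compound 3 is therefore expected to stay close to compound 2, with a step of about a number 5 percentage points higher from compound 2 to compound 3 (within the scatter). The estimated maximal response for compound 3 is 85%, between 65% and 100%.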

Compound 3, largest response reached (reported as efficacy), in percent of the reference or control that the assay uses: 81%
Compound 3: middle estimate off by 4 percentage points, on the high side, within the range that was stated.
By their numbers in this assay, from the lowest: compounds 2 and 3 (each within the scatter of the next); then compound 1.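

In this assay, the exchange of 1-(trifluoromethyl)ethoxy for isopropylsulfanyl on the carbonyl carbon gives a number 1 percentage points higher from compound 2 to compound 3 (within the scatter), so this change, which replaces the linking oxygen with sulfur and removes all three fluorines and the defined stereocentre, leaves the maximal response within the scatter. The comparison with the cyano-bearing group gives a number 16 percentage points lower from compound 1 to compound 3 (beyond the scatter), which leaves compound 1 apart from both other compounds, with its steps to each beyond the scatter. No measurement here explains either step.

The compounds shown do not separate the effect of the linking atom from that of the groups further out on it, as the sulfur and oxygen compounds also differ in those groups. On these data alone, how isopropoxy, or an amine such as dimethylamino, on this carbonyl carbon would read remains open.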